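Moving a chlorine on the anilino ring of compound 3

The source may report more compounds than this note shows. Statements on the series, on what has been measured and on what is new or still open speak of the compounds shown alone.

Compound 3 `Cc1n[nH]c2ccc(-c3nc4cnc(N5CCN(C)CC5)cn4c3Nc3ccc(Cl)cc3Cl)cc12` stands highest of the three compounds measured in a functional assay on MV4-11 cells (Homo sapiens) for inhibition, with a stated time of 120 h, tested at 10 uM (on this read-out lower numbers stand for less inhibition and higher numbers for more inhibition at the one concentration tested (going by the name of the read-out)), where compound 3 gives 78.8%. Compound 1 `Cc1n[nH]c2ccc(-c3nc4cnc(N5CCN(C)CC5)cn4c3Nc3ccccc3Cl)cc12` gives 58.1% in this assay, and compound 2 `COc1ccc(Nc2c(-c3ccc4[nH]nc(C)c4c3)nc3cnc(N4CCN(C)CC4)cn23)cc1` gives 3.32%. The step of a number 20.7 percentage points higher from compound 1 to compound 3 (beyond the scatter) followed from chloro in place of hydrogen on an aromatic carbon, while the step of a number 54.8 percentage points lower from compound 1 to compound 2 (beyond the scatter) followed from 4-methoxyphenyl in place of 2-chlorophenyl on a nitrogen on an aromatic ring, and the step of a number 75.5 percentage points higher from compound 2 to compound 3 (beyond the scatter) followed from 2,4-dichlorophenyl in place of 4-methoxyphenyl on a nitrogen on an aromatic ring.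

Compound 4 `Cc1n[nH]c2ccc(-c3nc4cnc(N5CCN(C)CC5)cn4c3Nc3cc(Cl)ccc3Cl)cc12` differs from compound 3 only in where the second chlorine sits: 2,5-dichlorophenyl in place of 2,4-dichlorophenyl on a nitrogen on an aromatic ring. Among the compounds with values here, no measured step moves a chlorine from one aromatic carbon to another, so none bears on it directly. The steps show that the group on the nitrogen matters greatly, yet compound 3 and compound 1 both carry chlorine and both inhibit well, so a step within or close to the scatter is expected from compound 3 to compound 4, a number 8.8 percentage points lower from compound 3 to compound 4 (within the scatter). Compound 4 is therefore estimated to give 70% in this assay, between 45% and 90%.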

Compound 4, a percentage reported as inhibition, at one concentration (the size of the read-out at that concentration, not a potency): 23.8%
Compound 4: the middle estimate sits 46.2 percentage points above what was measured, and the stated range ends above it.
By their numbers in this assay, from the lowest: compound 2; then compound 4; then compound 1; then compound 3.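

Swapping 2,4-dichlorophenyl for 2,5-dichlorophenyl on the nitrogen keeps the same atoms, yet this assay gives (a number 55 percentage points lower from compound 3 to compound 4 (beyond the scatter)), so the place of the second chlorine alone can decide much of the inhibition. Adding a chloro to the 2-chlorophenyl of compound 1 also has no single direction: the read-out gives (a number 20.7 percentage points higher from compound 1 to compound 3 (beyond the scatter)) for the 2,4-dichlorophenyl but (a number 34.3 percentage points lower from compound 1 to compound 4 (beyond the scatter)) for the 2,5-dichlorophenyl. The 2,5-dichlorophenyl still keeps some advantage over the 4-methoxyphenyl (a number 20.5 percentage points higher from compound 2 to compound 4 (beyond the scatter)), so the two chlorines of compound 4 give less than compound 1 with its one chlorine, but more than the methoxy group of compound 2.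

Nothing in the data at hand accounts for why these two dichlorophenyl groups part so far.

Also open, from the compounds shown here alone, is whether the gain seen with compound 3 belongs to chlorine itself or would follow with a 2-chloro-4-fluorophenyl, a 2-chloro-4-methylphenyl or a 2-chloro-4-cyanophenyl on the same nitrogen, and how a 2-chloro-5-fluorophenyl would compare with compound 4.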